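Trifluoromethyl in place of bromo: a cytotoxicity step

The source may report more compounds than this note shows. Statements on the series, on what has been measured and on what is new or still open speak of the compounds shown alone.

Compound 1 `Fc1ccc2[nH]c(-c3cn(-c4ccccc4)nc3-c3ccccc3)nc2c1` gives > 50000 nM (a limit)
Compound 2 `Brc1ccc2[nH]c(-c3cn(-c4ccccc4)nc3-c3ccccc3)nc2c1` gives > 50000 nM (a limit)

In an ADME assay on HaCaT cells (Homo sapiens) for cytotoxicity, read by MTT assay, with a stated time of 48 h (on this read-out higher numbers stand for weaker inhibition and lower numbers for stronger inhibition), compound 2 gives > 50000 nM, which is a limit of the assay and not a number. It therefore stands at the limit of > 50000 nM in this assay, at which 2 of the 2 values shown sit.

Compound 3 `FC(F)(F)c1ccc2[nH]c(-c3cn(-c4ccccc4)nc3-c3ccccc3)nc2c1` carries trifluoromethyl in place of bromo on an aromatic carbon. Among the compounds with values here, only one measured step bears on this change: a step that the two limits leave unreadable from compound 1 to compound 2, with bromo in place of fluoro. It gives no size to carry over, so no step beyond the scatter is expected in this assay, and no direction can be predicted. Another limit is the likeliest report for compound 3. Compound 3 is estimated at 50000 nM, with an expected range from 20000 nM to 100000 nM. This estimate means an expected a number no higher from compound 2 to compound 3 (the limit leaves the size open).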

Compound 3, half-maximal inhibitory concentration: 37200 nM
For compound 3 the middle estimate is 1.3-fold (0.13 log units) above the measured one; measured number inside the range.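

In this assay, within the data shown here, compound 3 is the only one of the three compounds to give a measured number rather than a limit, at 37200 nM. Trifluoromethyl in place of bromo gives an at least 1.3-fold lower number from compound 2 to compound 3 (0.12 log units; that floor lies within the scatter), and trifluoromethyl in place of fluoro gives an at least 1.3-fold lower number from compound 1 to compound 3 (0.12 log units; that floor lies within the scatter). Neither step is shown to go beyond the scatter, so this change at this position is not shown to alter cytotoxicity by any real amount, and the comparison rests on limits for the other two compounds: the limit of > 50000 nM in this assay, at which 2 of the 3 values shown sit.

The compounds shown leave open how an amine, a methoxy group or a carboxylic acid would read on this same aromatic carbon. They also leave open whether a change elsewhere on the shared core would give a step beyond the scatter.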